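The source may hold more compounds than are shown below. What is called first, only, known or untested is meant among the compounds shown, and "the series" means these compounds.

In a functional assay on LNCaP cells (Homo sapiens) for antiproliferative activity, read by propidium iodide staining, with a stated time of 96 h (a higher number here means a weaker inhibitor, a lower number a stronger inhibitor), compound 1 (`CC(O)(CSc1cccc(C(F)(F)F)c1)C(=O)Nc1cccc(S(F)(F)(F)(F)F)c1`) gives 12700 nM and compound 2 (`CC(O)(CS(=O)(=O)c1cccc(C(F)(F)F)c1)C(=O)Nc1ccc(S(F)(F)(F)(F)F)cc1`) gives 21000 nM while compound 3 (`CC(O)(CS(=O)(=O)c1cc(C(F)(F)F)cc(C(F)(F)F)c1)C(=O)Nc1ccc(S(F)(F)(F)(F)F)cc1`) gives 13300 nM so that compound 3 sits level with both, within the scatter. The change to compound 4 (`CC(O)(CS(=O)(=O)c1cc(C(F)(F)F)cc(C(F)(F)F)c1)C(=O)Nc1cccc(S(F)(F)(F)(F)F)c1`) is a group of 12 heavy atoms (6 carbon, 5 fluorine, 1 sulfur; one six-membered aromatic ring of carbon only) in place of a group of 12 heavy atoms (6 carbon, 5 fluorine, 1 sulfur; one six-membered aromatic ring of carbon only), on an amide-type nitrogen and the two hold the same atoms, joined differently. For the measured compounds named here, the only measured step (a 1.6-fold lower number from compound 2 to compound 3 (0.20 log units; within the scatter)) is a different change and stays within the scatter. Compound 1 already carries the entering group on its amide-type nitrogen, though it differs elsewhere, and its value (12700 nM) is level with that of compound 3 (13300 nM). No step beyond the scatter is therefore expected in this assay (estimated: a 1.0-fold lower number from compound 3 to compound 4 (0.01 log units; within the scatter)). For compound 4 the estimated value is 13000 nM (expected range 6000 nM to 28000 nM).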

Compound 4, half-maximal inhibitory concentration: 9700 nM
The estimate for compound 4 lay 1.3-fold (0.13 log units) above the measured number; the range from low to high includes it.
By their numbers in this assay, from the lowest: compounds 4, 1, 3 and 2 (each within the scatter of the next, the first and the last beyond it).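

In this assay, the exchange on the amide-type nitrogen gives a 1.4-fold lower number from compound 3 to compound 4 (0.14 log units; within the scatter). For the compounds shown here, this is the first comparison in which these two groups, which hold the same atoms joined differently, stand on an otherwise identical compound, and the exchange leaves the number within the scatter. Nothing measured here accounts for this result. The compounds shown leave open whether the same exchange would stay within the scatter on the core of compound 2. They also leave open how a nitrile or a carboxylic acid would compare with either group on that aromatic ring.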